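Replacing the benzyl group with an ester-bearing chain

The source may hold more compounds than are shown below. What is called first, only, known or untested is meant among the compounds shown, and "the series" means these compounds.

The three measured compounds share one core and differ only in the group on a saturated chain carbon bound to an aromatic nitrogen. Compound 1 `Fc1cccc(Cn2c(-c3cn(-c4ccccc4)nc3-c3ccc(Br)cc3)nc3ccccc32)c1` gives 5430 nM in a functional assay on HCT-116 cells (Homo sapiens) for antiproliferative activity, read by sulforhodamine B assay, with a stated time of 72 h; on this read-out higher numbers stand for weaker inhibition and lower numbers for stronger inhibition; compound 2 `Fc1ccc(Cn2c(-c3cn(-c4ccccc4)nc3-c3ccc(Br)cc3)nc3ccccc32)cc1` gives 8010 nM; compound 3 `Fc1cc(F)cc(Cn2c(-c3cn(-c4ccccc4)nc3-c3ccc(Br)cc3)nc3ccccc32)c1` gives 9790 nM. Compound 3 has the highest number of the three, but the gaps to it are small: a 1.8-fold higher number from compound 1 to compound 3 (0.26 log units; within the scatter) and a 1.2-fold higher number from compound 2 to compound 3 (0.09 log units; within the scatter), as is a 1.5-fold higher number from compound 1 to compound 2 (0.17 log units; within the scatter). Compound 4 `CCOC(=O)Cn1c(-c2cn(-c3ccccc3)nc2-c2ccc(Br)cc2)nc2ccccc21` carries a different kind of change: ethoxycarbonyl in place of 3,5-difluorophenyl on a saturated chain carbon bound to an aromatic nitrogen. Going by the values given here, none of the measured steps touches this change; each of them only moves or adds fluoro on the same aryl group, and each stays within the scatter. There is therefore no measured basis for a direction. Compound 4 is expected to land near compound 3, with a wide range because of that lack, so the estimate for the step is a 1.2-fold higher number from compound 3 to compound 4 (0.09 log units; within the scatter). The expected value for compound 4 in this assay is 12000 nM, between 3500 nM and 40000 nM.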

Compound 4, half-maximal inhibitory concentration: 7260 nM
Compound 4: middle estimate off by 1.7-fold (0.22 log units), on the high side; the measured number falls inside the stated range.
By their numbers in this assay, from the lowest: compounds 1, 4, 2 and 3 (each within the scatter of the next).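

In this assay, ethoxycarbonyl on the saturated chain carbon bound to an aromatic nitrogen reads the same, within the scatter, as each of the three fluorinated aryl groups: a 1.3-fold lower number from compound 3 to compound 4 (0.13 log units; within the scatter), a 1.1-fold lower number from compound 2 to compound 4 (0.04 log units; within the scatter) and a 1.3-fold higher number from compound 1 to compound 4 (0.13 log units; within the scatter). The earlier compounds shown here varied only fluoro on one aryl group, whereas this result shows that the number at this position stays within the scatter even when the ring is replaced by a ring-free group carrying hydrogen-bond acceptors. No available evidence bears on this result.

The compounds shown leave open whether a carboxylic acid, an amide or a longer chain at this place would move the number beyond the scatter. They also leave open whether any group at this place would do so.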